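Reversing the hydrazone and swapping the benzoyl substituent

The compounds below may be only part of what the source reports. "The series", "measured", "known", "first", "only" and "open" are said of these compounds alone.

Compounds measured in a functional assay (MiaPaCa cells, Homo sapiens) for inhibition, read by sulforhodamine B assay, with a stated time of 48 h; on this read-out lower numbers stand for stronger inhibition of growth and higher numbers for weaker inhibition of growth:
compound 1 (`Cc1ccc(/C=N\NC(=O)C2=C(Cl)c3ccccc3CCC2)cc1`), < 10 nM;
compound 2 (`Cc1cc2c(cc1C)C(Cl)=C(/C=N\NC(=O)C1=C(Cl)c3ccccc3CCC1)CCC2`), 210 nM;
compound 3 (`Cc1ccc(C(=O)N/N=C/C2=C(Cl)c3cc(C)c(C)cc3CCC2)cc1`), 28800 nM.

For compound 1 this value is a limit, not a number: the limit of < 10 nM in this assay, at which 1 of the 3 values shown sits. Compound 3 stands highest of the two numbers in this assay, with compound 2 nearest and far lower, a gap beyond the scatter.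

Compound 4 (`Cc1cc2c(cc1C)C(Cl)=C(/C=N/NC(=O)c1cccc(Cl)c1)CCC2`) differs from compound 3 by 3-chlorophenyl in place of 4-methylphenyl on a carbonyl carbon. For the measured compounds named here, no measured pair isolates this change. Only a small step is expected, a 1.6-fold lower number from compound 3 to compound 4 (0.20 log units; within the scatter), not clearly beyond the scatter, with weak inhibition retained. Compound 4 is therefore estimated at 18000 nM in this assay, within a range from 5000 nM to 60000 nM.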

Compound 4, concentration for 50% growth inhibition: 33600 nM
The estimate for compound 4 lay 1.9-fold (0.27 log units) below the measured number; the measured number falls inside the stated range.
By their numbers in this assay, from the lowest: compound 2; then compounds 3 and 4 (each within the scatter of the next). At a limit, below all of these: compound 1.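

In this assay, for the compounds shown here, 3-chlorophenyl in place of 4-methylphenyl on a carbonyl carbon gives a 1.2-fold higher number from compound 3 to compound 4 (0.07 log units; within the scatter), the first comparison here of compounds differing in one place. At this position, the two groups cannot be told apart, and inhibition of growth stays weak. Nothing shown accounts for this result.

The compounds shown leave open whether a carboxylic acid, an amine or a longer chain in place of these rings on the carbonyl carbon would move the number beyond the scatter. They also leave open whether the same swap would matter on the core of compound 1.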